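Lengthening the ester chain of compound 3 by one carbon

The compounds below may be only part of what the source reports. "The series", "measured", "known", "first", "only" and "open" are said of these compounds alone.

- compound 1 `C=C[C@@](C)(/C=C/c1ccc(OC(=O)CC)cc1)CCC=C(C)C`: 42%
- compound 2 `C=C[C@@](C)(/C=C/c1ccc(OC(=O)CCC)cc1)CCC=C(C)C`: 50%
- compound 3 `C=C[C@@](C)(/C=C/c1ccc(OC(=O)CCCC)cc1)CCC=C(C)C`: 38%

All three compounds were tested in a functional assay on A549 cells (Homo sapiens) for inhibition, with a stated time of 48 h, tested at 50 uM; a lower number here means less inhibition of growth, a higher number more inhibition of growth at the concentration tested. There, compound 3 gives 38%. This places it within the scatter of compound 1, while compound 2 gives the higher 50%.

The next compound, compound 4 `C=C[C@@](C)(/C=C/c1ccc(OC(=O)CCCCC)cc1)CCC=C(C)C`, differs from compound 3 by methyl in place of hydrogen on a saturated chain carbon, four bonds along the chain from a carbonyl carbon. In words, this is methyl in place of hydrogen on a saturated chain carbon, four bonds along the chain from a carbonyl carbon, which also reads as propyl to butyl.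

Among the compounds with values here, three measured steps bear on this change. The first two are a number 8 percentage points higher from compound 1 to compound 2 (within the scatter) and a number 4 percentage points lower from compound 1 to compound 3 (within the scatter). The third, and the only one beyond the scatter, is a number 12 percentage points lower from compound 2 to compound 3 (beyond the scatter), and it is modest in size. These few steps show no steady trend with chain length, so they give no firm direction for one further extension.

The expected result is therefore no step beyond the scatter, with a slight drift at most: a number 2 percentage points lower from compound 3 to compound 4 (within the scatter) is the estimated step. Compound 4 is expected to give 36%, with an estimated range of 24% to 48%.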

Compound 4, percent growth inhibition at one concentration: 58%
Compound 4: the middle estimate sits 22 percentage points below what was measured, outside the stated range (above it).
By their numbers in this assay, from the lowest: compounds 3, 1, 2 and 4 (each within the scatter of the next, the first and the last beyond it).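

In this assay, lengthening the ester chain from propyl to butyl, with methyl in place of hydrogen on a saturated chain carbon, four bonds along the chain from a carbonyl carbon, gives a number 20 percentage points higher from compound 3 to compound 4 (beyond the scatter). The lower number at compound 3 therefore does not continue with the next extension: the result shows a number 8 percentage points higher from compound 2 to compound 4 (within the scatter), and it also separates the butyl ester from the shortest ester shown, with a number 16 percentage points higher from compound 1 to compound 4 (beyond the scatter). One-carbon extension has now given a higher number twice, yet compound 3 goes against any steady rise with chain length, and the two higher steps cannot be told apart: the same change on two cores in this assay, a number 8 percentage points higher (within the scatter) from compound 1 to compound 2 and a number 20 percentage points higher (beyond the scatter) from compound 3 to compound 4, 12 percentage points apart, within the scatter of two such steps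

The compounds shown leave open whether the number keeps rising, levels off or falls again with a chain longer than butyl, and whether the up-and-down pattern would hold on repeated measurement. They also do not show how a branched chain or an amide in place of the ester would read, and a single tested concentration gives no full concentration-response picture for any of these compounds.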